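This account rests on a few compounds, and the source may have more. Where it says the series, first, only, none or still open, it means among the compounds named here.

Compound 1, `CC(C)(C)OC(=O)/C=C1/C(=O)Nc2ccccc21` — 78.1%
Compound 2, `COc1cccc2c1NC(=O)/C2=C/C(=O)OC(C)(C)C` — 77.8%

In a functional assay on SW480 cells (Homo sapiens) for inhibition, read by CCK-8 assay, with a stated time of 72 h, tested at 20 uM (on this read-out higher numbers stand for more inhibition of growth at the one concentration tested and lower numbers for less inhibition of growth), compound 1 gives 78.1%, and compound 2 gives 77.8%. Compound 1 sits at one end of the pair of numbers, yet the step of a number 0.3 percentage points lower from compound 1 to compound 2 (within the scatter) lies within the scatter, so nothing separates the two compounds on this read-out.

Compound 3, `CC(C)(C)OC(=O)/C=C1/C(=O)Nc2ccc(Cl)cc21`, has not yet been measured in this assay. It differs from compound 1 by chloro in place of hydrogen on an aromatic carbon. Within the data shown here, the only measured step that bears on this change is another substitution of hydrogen on the same aromatic ring of the shared core, a number 0.3 percentage points lower from compound 1 to compound 2 (within the scatter), which stayed within the scatter. That step concerns a methoxy group on a different carbon, and no chloro substitution has been measured at all, so the comparison is indirect. On the basis available, compound 3 is expected to show no step beyond the scatter in this assay. Compound 3 is therefore estimated at 78%, with a range from 62% to 90%. The expected step is a number 0.1 percentage points lower from compound 1 to compound 3 (within the scatter).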

Compound 3, percent growth inhibition at one concentration: 78.5%
Estimate against measurement, compound 3: 0.5 percentage points below; low and high end bracket the measured number.
By their numbers in this assay, from the lowest: compounds 2, 1 and 3 (each within the scatter of the next).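

In this assay, chloro in place of hydrogen gives a number 0.4 percentage points higher from compound 1 to compound 3 (within the scatter) and so leaves the read-out unchanged at this position, on a carbon meta to a fused ring and para to a fused ring. Compound 2 had shown this only for methoxy on a different carbon of the same ring, so compound 3 adds a second group at a second place, and again the number stays level with that of compound 1 at the one concentration tested. No measurement shown here offers an explanation for this result.

The compounds shown leave open whether a group of a different kind at this position, such as an amine, a carboxylic acid or a longer chain, would also stay within the scatter. They also leave open whether chloro on the other carbons of this ring would behave as it does here, and whether any of these compounds would separate at concentrations other than the one tested.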